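The source may report more compounds than this note shows. Statements on the series, on what has been measured and on what is new or still open speak of the compounds shown alone.

Three ureas built on one shared core have been tested in a functional assay on T-24 cells (Homo sapiens) for antiproliferative activity, read by MTT assay, with a stated time of 48 h; a higher number here means a weaker inhibitor, a lower number a stronger inhibitor. Compound 1 `O=C(Nc1cccc(CNc2nccnc2Cl)c1)NC1CCCC1` carries a cyclopentyl group on the amide-type nitrogen. In this assay compound 1 gives only a limit, > 40000 nM, not a number. That reading is the limit of > 40000 nM in this assay, at which 1 of the 3 values shown sits. Compound 2 `O=C(Nc1cccc(CNc2nccnc2Cl)c1)Nc1cccc(C(F)(F)F)c1` gives 5080 nM in this assay, and compound 3 `CCc1ccc(NC(=O)Nc2cccc(CNc3nccnc3Cl)c2)c(CC)c1` gives 6390 nM. Both carry an aromatic ring on the amide-type nitrogen, and both return a number rather than a limit. Compound 4 `O=C(Nc1cccc(CNc2nccnc2Cl)c1)Nc1ccccc1Cl`, not yet measured, differs from compound 1 by 2-chlorophenyl in place of cyclopentyl on an amide-type nitrogen. For the measured compounds named here, compound 1 offers only a limit, so no measured step fixes the size of this change. The step from compound 1 to compound 4 is expected to be a clear gain in potency, an at least 6.6-fold lower number from compound 1 to compound 4 (0.82 log units; beyond the scatter). Compound 4 is expected to give about 6000 nM, within 2500 nM to 15000 nM.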

Compound 4, half-maximal inhibitory concentration: 6680 nM
Beside the measured number, compound 4's estimate is 1.1-fold (0.05 log units) below it, and the stated range covers the measured number.
By their numbers in this assay, from the lowest: compounds 2, 3 and 4 (each within the scatter of the next). At a limit, above all of these: compound 1.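

In this assay, for the compounds shown here, this is the first single change measured at this position: 2-chlorophenyl in place of cyclopentyl on an amide-type nitrogen gives an at least 5.9-fold lower number from compound 1 to compound 4 (0.77 log units; beyond the scatter). Compound 1 stands at a limit, so this step gives only a lower bound on the change and not its true size: the limit of > 40000 nM in this assay, at which 1 of the 4 values shown sits. Compounds 2, 3 and 4 all lie within the scatter of one another, so their different aromatic groups cannot be told apart here.

As far as these compounds go, what remains open is whether the ring or its chlorine carries the gain, which a plain phenyl group at this position would help to settle. Also unknown is how an aromatic ring bearing an amine or a carboxylic acid would behave there.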